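Replacing the chlorophenyl ketone chain with an ethoxybenzyl branch

The source may report more compounds than this note shows. Statements on the series, on what has been measured and on what is new or still open speak of the compounds shown alone.

The two measured compounds share one core and differ only in the group carried by the amide carbonyl. Compound 1 `Cc1ccc(OCC(=O)N2CCN(c3ccc(C(F)(F)F)cc3[C@@H](N)CC(C)C)CC2)c(C)c1` gives 4000 nM in an assay on HEK293 cells for displacement of a labelled ligand from Melanocortin receptor 4 (Homo sapiens) (on this read-out lower numbers stand for stronger inhibition and higher numbers for weaker inhibition), while compound 2 `CC(C)C[C@H](N)c1cc(C(F)(F)F)ccc1N1CCN(C(=O)CCC(=O)c2ccc(Cl)cc2)CC1` gives 820 nM, the lowest of the two numbers; the change was a 4.9-fold lower number from compound 1 to compound 2 (0.69 log units; beyond the scatter). Compound 3 `CCOc1cccc(CC(C)C(=O)N2CCN(c3ccc(C(F)(F)F)cc3[C@@H](N)CC(C)C)CC2)c1` carries 1-(3-ethoxybenzyl)ethyl in place of 2-((4-chlorophenyl)carbonyl)ethyl on a carbonyl carbon. Among the measured compounds shown here, only that single step bears on this change, and it does not involve the group entering here, so the step of a 1.8-fold higher number from compound 2 to compound 3 (0.26 log units; within the scatter) is expected to stay small and could run either way. Compound 3 is therefore estimated at 1500 nM, within 400 nM to 6000 nM.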

Compound 3, inhibition constant: 2200 nM
The estimate for compound 3 lay 1.5-fold (0.17 log units) below the measured number; measured number inside the range.
By their numbers in this assay, from the lowest: compound 2; then compounds 3 and 1 (each within the scatter of the next).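

Putting 1-(3-ethoxybenzyl)ethyl in place of 2-((4-chlorophenyl)carbonyl)ethyl on this carbonyl carbon gives a 2.7-fold higher number from compound 2 to compound 3 (0.43 log units; beyond the scatter), so the ketone chain of compound 2 keeps the lowest number. Against the (2,4-dimethylphenoxy)methyl group, the same branch gives a 1.8-fold lower number from compound 1 to compound 3 (0.26 log units; within the scatter), so these two quite different groups cannot be told apart on this read-out. From the compounds shown here alone, it remains open whether a shorter chain, or an amine in place of the ketone carbonyl, would bring the number lower than in compound 2. No evidence is available to explain these differences.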